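A Ring Returns to the Side Chain

The source may report more compounds than this note shows. Statements on the series, on what has been measured and on what is new or still open speak of the compounds shown alone.

Compound 2 `CN(C)CCCOc1ccc(-c2nc3ccc(Oc4ccc(Cl)cc4)cc3o2)cc1` gives the lower of the two numbers measured in an assay on isolated protein for inhibition of advanced glycosylation end product-specific receptor (Homo sapiens), read by FRET, with stated times of 30 min and 1 h, tested at 4 uM; a lower number here means less inhibition, a higher number more inhibition at the concentration tested (going by the name of the read-out): compound 2 gives 4.9%, while compound 1 `Clc1ccc(Oc2ccc3nc(-c4ccc(OC5CCNCC5)cc4)oc3c2)cc1` gives 20.6%. Within the data shown here, the only step known so far, a number 15.7 percentage points lower from compound 1 to compound 2 (beyond the scatter), came with the exchange of piperidin-4-yl for 3-(dimethylamino)propyl on an oxygen on an aromatic ring. Compound 3 `N[C@H]1CCN(CCCOc2ccc(-c3nc4ccc(Oc5ccc(Cl)cc5)cc4o3)cc2)C1` has not yet been measured. It differs from compound 2 in a single place: 3-aminopyrrolidin-1-yl in place of dimethylamino on a saturated chain carbon, three bonds along the chain from an oxygen on an aromatic ring. Among the measured compounds shown here, the one step that bears on this is the one from compound 1, where the group carrying a ring and a hydrogen-bond donor gave the higher reading; compound 3 brings a ring with a hydrogen-bond donor back, but on the chain three bonds from the oxygen rather than directly on it, so only a partial return toward the reading of compound 1 is expected, if any. The expected step of a number 7.1 percentage points higher from compound 2 to compound 3 (within the scatter) is small, near the edge of the scatter. For compound 3 the estimate in this assay is 12%, with a range from 0% to 28%.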

Compound 3, a percentage reported as inhibition, at one concentration (the size of the read-out at that concentration, not a potency): 29.9%
For compound 3 the middle estimate is 17.9 percentage points below the measured one; measured number outside the range, above it.
By their numbers in this assay, from the lowest: compound 2; then compounds 1 and 3 (each within the scatter of the next).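

In this assay, the place on a saturated chain carbon, three bonds along the chain from an oxygen on an aromatic ring, proved responsive: 3-aminopyrrolidin-1-yl in place of dimethylamino gave a number 25 percentage points higher from compound 2 to compound 3 (beyond the scatter), so the low reading of compound 2 does not hold for every group carried on this propyl chain. Nor does a ring set directly on the oxygen appear to be required, as the exchange of piperidin-4-yl for 3-(3-aminopyrrolidin-1-yl)propyl gave a number 9.3 percentage points higher from compound 1 to compound 3 (within the scatter), which leaves the two compounds indistinguishable in this assay. Nothing available explains why either exchange affects the reading.

The ring, the primary amine and the defined stereocentre all enter together in compound 3, so the compounds shown cannot say which of them accounts for the step from compound 2. A plain pyrrolidin-1-yl group or an open-chain primary amine at the end of the propyl chain would separate the ring from the amine, while the opposite stereoisomer of 3-aminopyrrolidin-1-yl would test the stereocentre.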